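The source may hold more compounds than are shown below. What is called first, only, known or untested is meant among the compounds shown, and "the series" means these compounds.

Of the compounds shown here, three have been tested in an assay on BaF3 cells with thrombopoietin receptor (Homo sapiens) as the target, read by a luciferase reporter; a higher number here means a larger maximal response, a lower number a smaller maximal response. Compound 1, `O=C(O)c1cccc2c(/N=N/c3c(O)cc(S(=O)(=O)O)c4ccccc34)c(O)ccc12`, gives in this assay a result that is a limit of the assay rather than a number, < 5%. Compound 2, `O=S(=O)(O)c1cc(O)c(NCc2c(O)ccc3ccccc23)c2ccccc12`, likewise reaches only the limit of the assay, < 5%. Compound 3, `Cc1[nH]n(C(C)(C)C)c(=O)c1/N=N/c1c(O)cc(S(=O)(=O)O)c2ccccc12`, stands at the same limit in this assay, < 5%, so no measured maximal response is known for it. All three results share that limit, (the limit of < 5% in this assay, at which 3 of the 3 values shown sit). No pair of these compounds differs in only one place, so no single step has been measured, and nothing shows how far a change of one group moves the maximal response.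

Compound 4, `Cc1[nH]n(-c2ccc(C(=O)O)cc2)c(=O)c1/N=N/c1c(O)cc(S(=O)(=O)O)c2ccccc12`, is not yet measured. It differs from compound 3 in one place: 4-carboxyphenyl in place of tert-butyl on an aromatic nitrogen. For the measured compounds named here, with every measured compound at the limit and no measured step to lean on, the expected step in this assay, a step that the limit leaves unreadable from compound 3 to compound 4, means no change beyond the scatter is expected. Compound 4 is therefore expected to give in this assay about 4%, with a range from 0% to 15%, and most probably will again be reported only as a limit.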

Compound 4, largest response reached (reported as efficacy), in percent of the reference or control that the assay uses: < 5%
Compound 4 gave a limit, no number; the forecaster's own chance of this, stated with the estimate: 70%; the middle value lies beyond the limit too.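

In this assay compound 4 gives < 5%, which is a limit of the assay and not a number. For the compounds shown here, compound 3 also sits at a limit, so no step from compound 3 to compound 4 can be read. All the results share one limit: the limit of < 5% in this assay, at which 4 of the 4 values shown sit. The compounds shown leave open which structural change, if any, would give a measurable maximal response.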